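A few compounds are considered here, and "the series" means these few. Any claim that something is new, unique, unknown or untested is made for them only; others in the source may bear on it.

In a functional assay on T47D cells (Homo sapiens) for cytotoxicity, read by CCK-8 assay and cell counting, with a stated time of 72 h (a lower number here means a stronger inhibitor, a higher number a weaker inhibitor), compound 1, whose structure is `COc1ccc(-c2cc3ccccc3c(-c3cccc(N)c3)n2)cc1`, gives 950 nM. Compound 2, with structure `COc1ccc(-c2cc3ccccc3c(-c3ccc(O)cc3)n2)cc1`, is the same molecule except for one exchange, (4-hydroxyphenyl in place of 3-aminophenyl on an aromatic carbon), and in this assay compound 2 gives 1220 nM. The step of a 1.3-fold higher number from compound 1 to compound 2 (0.11 log units; within the scatter) is therefore small, and nothing can be read into its direction.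

Compound 3, with structure `COc1cc(OC)cc(-c2cc3ccccc3c(-c3cccc(N)c3)n2)c1`, carries a different core; the difference between the core of compound 1 and the core of compound 3 is not broken down here. In this assay, among the compounds with values here, compound 3 gives 980 nM, a number that lies within the scatter of the one for compound 1.

Compound 4, with structure `COc1cc(OC)cc(-c2cc3ccccc3c(-c3ccc(O)cc3)n2)c1`, has not yet been measured. It differs from compound 3 by 4-hydroxyphenyl in place of 3-aminophenyl on an aromatic carbon. Within the data shown here, this is the same kind of change as the one from compound 1 to compound 2, though the surroundings are described a little differently: in compound 1 the place is meta to a 4-methoxyphenyl group (8 heavy atoms), while in compound 3 it is meta to a large group.

Among the measured compounds shown here, because the only measured example of this exchange gave a 1.3-fold higher number from compound 1 to compound 2 (0.11 log units; within the scatter), the step from compound 3 to compound 4 is expected to be similar, about a 1.3-fold higher number from compound 3 to compound 4 (0.11 log units; within the scatter). On that basis compound 4 is estimated to give 1250 nM in this assay, most likely somewhere between 700 nM and 2300 nM.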

Compound 4, half-maximal inhibitory concentration: 780 nM
Estimate against measurement, compound 4: 1.6-fold (0.20 log units) above, within the range that was stated.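

In this assay, exchanging 3-aminophenyl for 4-hydroxyphenyl on the core of compound 3 gives a 1.3-fold lower number from compound 3 to compound 4 (0.10 log units; within the scatter), so this step is also small and its direction carries no meaning. Set beside the step on the core of compound 1, it does not differ from it: the same change on two cores in this assay, a 1.3-fold higher number (0.11 log units; within the scatter) from compound 1 to compound 2 and a 1.3-fold lower number (0.10 log units; within the scatter) from compound 3 to compound 4, 1.6-fold (0.21 log units) apart, within the scatter of two such steps On these two cores, then, the exchange can be carried across with no detectable effect on the number, but this shows only that two small steps agree; it does not show that the same would hold on a third core, and, with no step beyond the scatter, it gives no sign of how much either group contributes to the cytotoxicity.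

All four compounds shown carry either 3-aminophenyl or 4-hydroxyphenyl at this place, so it remains open whether a plain phenyl, a phenyl bearing a carboxylic acid or a longer chain, or a saturated ring such as piperidine would move the number beyond the scatter. Going by these compounds, it also remains open whether the exchange would stay this small on other cell lines, since every number here comes from this assay.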